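Swapping the thiophene partner of compound 2 for a dimethylaminophenyl

A few compounds are considered here, and "the series" means these few. Any claim that something is new, unique, unknown or untested is made for them only; others in the source may bear on it.

Three pyridinone nitriles have been measured in a functional assay for inhibition, tested at 80 ug/mL; on this read-out higher numbers stand for a stronger effect at the one concentration tested and lower numbers for a weaker effect. Compound 1 `COc1cc(OC)c(-c2cc(-c3cc(C(C)C)c(O)cc3C)[nH]c(=O)c2C#N)c(OC)c1` gives 79% in this assay. Compound 3 `COc1cc(-c2cc(-c3cc(C(C)C)c(O)cc3C)[nH]c(=O)c2C#N)cc(OC)c1OC` gives 82% in this assay. Compound 2 `Cc1cc(O)c(C(C)C)cc1-c1cc(-c2cccs2)c(C#N)c(=O)[nH]1` gives 63% in this assay, the lowest of the three numbers: compound 1 lies higher by a margin beyond the usual scatter, and compound 3 lies higher still, also beyond the scatter. No two of these compounds differ from each other in only one place, so no single step between measured compounds can be isolated.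

Compound 4 `Cc1cc(O)c(C(C)C)cc1-c1cc(-c2ccc(N(C)C)cc2)c(C#N)c(=O)[nH]1` has not yet been measured. Compared with compound 2 it differs in one place: 4-(dimethylamino)phenyl in place of thiophen-2-yl on an aromatic carbon

Compounds 1 and 3, which carry a six-membered aromatic ring of carbon only at the corresponding position, both give higher numbers than compound 2. Among the measured compounds shown here, on that basis compound 4 is expected to move upward, with the step from compound 2 to compound 4 estimated at a number 13 percentage points higher from compound 2 to compound 4 (beyond the scatter), a gain beyond the scatter but uncertain in size, since the dimethylamino substitution has no measured precedent here. Compound 4 is therefore expected to give 76% in this assay, within a range from 58% to 90%.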

Compound 4, a percentage reported as inhibition, at one concentration (the size of the read-out at that concentration, not a potency): 66.5%
Compound 4: middle estimate off by 9.5 percentage points, on the high side; measured number inside the range.
By their numbers in this assay, from the lowest: compounds 2 and 4 (each within the scatter of the next); then compounds 1 and 3 (each within the scatter of the next).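

In this assay, among the compounds shown here, placing 4-(dimethylamino)phenyl instead of thiophen-2-yl on the aromatic carbon opposite the ring nitrogen gives a number 3.5 percentage points higher from compound 2 to compound 4 (within the scatter) as the first step at this position that can be read on its own. The exchange of a five-membered aromatic ring with one hetero atom for a six-membered aromatic ring of carbon only, carrying a dimethylamino group and bringing more heavy atoms, therefore leaves the read-out at this one concentration unchanged within the usual scatter. Nothing available explains this outcome.

From the compounds shown here alone, it remains open whether an unsubstituted phenyl ring at this position, or a phenyl ring carrying a methoxy group or a carboxylic acid in place of the dimethylamino group, would give a step beyond the scatter. A single step with one replacement also leaves open whether the same exchange would behave alike on a core with a different group in place of the isopropyl or the hydroxyl.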